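The source may report more compounds than this note shows. Statements on the series, on what has been measured and on what is new or still open speak of the compounds shown alone.

In a physicochemical assay for lipophilicity, using the shake flask method, in phosphate buffer, measured as octanol-water partition, with a stated time of 85 min, at pH 7.4 (a lower number here means a more polar compound, a higher number a more lipophilic compound), the three measured compounds stand as follows:

compound 1 `O=Cc1ccc(-c2cn3ccnc3c(-c3ccc4ncn(C5CCCCC5)c4c3)n2)cc1` gives 1.5
compound 2 `O=Cc1ccc(-c2cn3ccnc3c(-c3ccc4ncn(Cc5ccccc5)c4c3)n2)cc1` gives 1.88
compound 3 `c1cn2cc(-c3ccc4c(c3)ncn4C3CCCCC3)nc(-c3ccc4ncn(C5CCCCC5)c4c3)c2n1` gives 1.9

Compound 1 and compound 2 share a core and differ in one place: benzyl in place of cyclohexyl on an aromatic nitrogen. That change gave a number 0.38 log units higher from compound 1 to compound 2 (beyond the scatter). Compound 3 has a different core; how it differs from the core of compound 1 is not broken down here. Compound 3 and compound 2 lie within the scatter of each other, while compound 3 sits beyond the scatter from compound 1.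

Compound 4 `c1ccc(Cn2cnc3ccc(-c4nc(-c5ccc6c(c5)ncn6C5CCCCC5)cn5ccnc45)cc32)cc1` has not yet been measured in this assay. For the measured compounds named here, it differs from compound 3 by benzyl in place of cyclohexyl on an aromatic nitrogen, the same change as the one from compound 1 to compound 2, at a place described in the same words. Because the measured step was a number 0.38 log units higher from compound 1 to compound 2 (beyond the scatter), a step of similar size is expected from compound 3 to compound 4, namely a number 0.38 log units higher from compound 3 to compound 4 (beyond the scatter). Compound 4 is therefore estimated at 2.28, expected to fall between 1.9 and 2.7.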

Compound 4, partition coefficient: 1.61
Beside the measured number, compound 4's estimate is 0.67 log units above it; measured number outside the range, below it.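

In this assay, benzyl in place of cyclohexyl on an aromatic nitrogen gave a number 0.38 log units higher from compound 1 to compound 2 (beyond the scatter) on the first core, while the same change on the second gave a number 0.29 log units lower from compound 3 to compound 4 (within the scatter) and so left that pair unresolved by this measurement. For the compounds shown here, this shows that the step seen on one core did not reappear on the other, so its size cannot simply be carried across cores; with only two pairs, however, it does not establish a general rule for the change. No measurement shown bears on why the two cores behave differently.

The compounds shown leave open how other groups on that aromatic nitrogen, such as a longer carbon chain or a chain ending in an amine, would behave on each core. With one pair per core, they also leave open which of the two results is more typical of this change.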